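A few compounds are considered here, and "the series" means these few. Any claim that something is new, unique, unknown or untested is made for them only; others in the source may bear on it.

Measured compounds:
compound 1, `O=c1c2ccccc2[se]n1-c1nnc(-c2ccc(Cl)cc2)s1`, 19500 nM
compound 2, `O=c1c2ccccc2[se]n1-c1nnc(-c2ccc(F)cc2)s1`, 61500 nM

In a functional assay on MCF7 cells (Homo sapiens) for antiproliferative activity, read by CCK-8 assay, with a stated time of 48 h (a lower number here means a stronger inhibitor, a higher number a weaker inhibitor), compound 1 gives 19500 nM, and in this assay compound 2 gives 61500 nM, the higher of the two measured numbers. For the measured compounds named here, the one measured step, a 3.2-fold higher number from compound 1 to compound 2 (0.50 log units; beyond the scatter), shows that exchanging chloro for fluoro on the aromatic carbon raised the number by a modest but real margin.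

Compound 3, `O=c1c2ccccc2[se]n1-c1nnc(-c2ccccc2Cl)s1`, has not yet been measured in this assay. It differs from compound 2 by 2-chlorophenyl in place of 4-fluorophenyl on an aromatic carbon. Going by the values given here, this change brings chloro back, which is the part of the step from compound 1 to compound 2 run in reverse, but it also moves the halogen to a different position on the phenyl ring, and no measured pair shows what such a move does. On the halogen alone, compound 3 is expected to come in lower than compound 2, roughly back toward compound 1, because of a 3.2-fold higher number from compound 1 to compound 2 (0.50 log units; beyond the scatter); the positional change adds uncertainty in both directions. Compound 3 is therefore estimated at 25000 nM, within 8000 nM to 80000 nM, an expected step of a 2.5-fold lower number from compound 2 to compound 3 (0.39 log units; beyond the scatter).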

Compound 3, half-maximal inhibitory concentration: 4430 nM
Compound 3: middle estimate off by 5.6-fold (0.75 log units), on the high side, outside the stated range (below it).
By their numbers in this assay, from the lowest: compound 3; then compound 1; then compound 2.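

Within this assay the halogen stays chloro while 2-chlorophenyl replaces 4-chlorophenyl, and this gives a 4.4-fold lower number from compound 1 to compound 3 (0.64 log units; beyond the scatter) on the same aromatic carbon of the five-membered ring. The earlier pair showed only that the identity of the halogen mattered here, whereas this step shows that its place on the phenyl ring also matters, and the printed step is beyond the scatter. Together with the exchange of halogen, the change from 4-fluorophenyl to 2-chlorophenyl amounts to a 14-fold lower number from compound 2 to compound 3 (1.14 log units; beyond the scatter) and is the largest difference among the three compounds, larger than the change of halogen alone, which was a 3.2-fold higher number from compound 1 to compound 2 (0.50 log units; beyond the scatter) in the opposite direction; nothing available explains why this arrangement gives the lowest number.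

The compounds shown leave open whether fluoro would gain in the same way if it stood where chloro stands in compound 3, so the effects of halogen and position cannot yet be separated. They also leave open how a group other than a halogen on the phenyl ring, such as methoxy, an amine or a carboxylic acid, would compare with 2-chlorophenyl.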